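A few compounds are considered here, and "the series" means these few. Any claim that something is new, unique, unknown or untested is made for them only; others in the source may bear on it.

Measured compounds in a functional assay on ACHN cells (Homo sapiens) for cytotoxicity, read by sulforhodamine B assay, tested at 10 uM; on this read-out lower numbers stand for less inhibition and higher numbers for more inhibition at the one concentration tested (going by the name of the read-out):
compound 1 `CCCc1cc(-c2cn([C@H]3C[C@H](OC(C)=O)[C@@H](COC(C)=O)O3)c(=O)[nH]c2=O)on1`, 99.5%
compound 2 `CCCCCc1cc(-c2cn([C@H]3C[C@H](OC(C)=O)[C@@H](COC(C)=O)O3)c(=O)[nH]c2=O)on1`, 99.8%
compound 3 `CC(=O)OC[C@H]1O[C@@H](n2cc(-c3cc(-c4ccc(C(C)(C)C)cc4)no3)c(=O)[nH]c2=O)C[C@@H]1OC(C)=O`, 74.7%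

Compound 3 stands lowest of the three: against compound 1 the step is a number 24.8 percentage points lower from compound 1 to compound 3 (beyond the scatter), and against compound 2 it is a number 25.1 percentage points lower from compound 2 to compound 3 (beyond the scatter), while compound 1 and compound 2 sit within the scatter of each other, a number 0.3 percentage points higher from compound 1 to compound 2 (within the scatter). Compound 4 `CC(=O)OC[C@H]1O[C@@H](n2cc(-c3cc(-c4ccccc4)no3)c(=O)[nH]c2=O)C[C@@H]1OC(C)=O` differs from compound 3 by hydrogen in place of tert-butyl on an aromatic carbon, on an aromatic carbon of a six-membered aromatic ring of carbon only. Among the compounds with values here, no measured step removes a tert-butyl; the two steps that bear on it only show that the 4-(tert-butyl)phenyl arm lowers the inhibition relative to propyl or pentyl. Compound 4 is therefore expected to move partway back, a number 9.3 percentage points higher from compound 3 to compound 4 (within the scatter), with an estimate of 84% for compound 4 in this assay, between 58% and 100%.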

Compound 4, a percentage reported as inhibition, at one concentration (the size of the read-out at that concentration, not a potency): 97.6%
The estimate for compound 4 lay 13.6 percentage points below the measured number; the measured number falls inside the stated range.
By their numbers in this assay, from the lowest: compound 3; then compounds 4, 1 and 2 (each within the scatter of the next).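

In this assay, the lower number of compound 3 traces to the tert-butyl and not to the phenyl ring that carries it: hydrogen in its place gives a number 22.9 percentage points higher from compound 3 to compound 4 (beyond the scatter). The bare phenyl arm reads the same as the alkyl arms, with a number 2.2 percentage points lower from compound 2 to compound 4 (within the scatter) and a number 1.9 percentage points lower from compound 1 to compound 4 (within the scatter). Nothing measured here explains the effect of the tert-butyl. Going by these compounds, it remains open whether a methyl, an amine or a carboxylic acid on that same aromatic carbon would lower the number as tert-butyl does.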